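The compounds below may be only part of what the source reports. "The series", "measured", "known", "first", "only" and "open" are said of these compounds alone.

Compound 1 `c1cc(-c2cn[nH]c2)c2c(c1)C(c1ncc[nH]1)CC2` is the reference point of this small set. In a functional assay on CHO cells for agonist activity at Alpha-1A adrenergic receptor (Homo sapiens), read by FLIPR and calcium flux (a higher number here means that more compound is needed for the effect, a lower number that less compound is needed), compound 1 gives 14 nM, the lowest of the two single numbers in hand. The nearest neighbour, compound 2 `Cc1ccc2c(c1NS(C)(=O)=O)CCC2c1ncc[nH]1`, gives 33 nM in this assay, a gap that lies beyond the usual scatter of the method. Compound 3 `CS(=O)(=O)Nc1cccc2c1CCCC2c1ncc[nH]1` carries no single number: its repeated readings in this assay are 2150 nM; 142 nM; 234 nM (3 entries), and the spread among them the several entries of compound 3 in this assay, 2150 nM; 142 nM; 234 nM (3 entries) is wide enough that compound 3 is best regarded as weaker than compound 1 without a fixed distance.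

Compound 4 `Cn1nccc1-c1cccc2c1CCC2c1ncc[nH]1` shares the core of compound 1 and differs from it at one place, where the change is 1-methyl-1H-pyrazol-5-yl in place of 1H-pyrazol-4-yl on an aromatic carbon. For the measured compounds named here, no measured pair in this set reports exactly this kind of exchange, so the expectation for compound 4 rests on the change itself: the group that leaves offers a hydrogen-bond donor, the group that enters offers none, and the point of attachment on the five-membered ring also shifts. A modest loss of potency is expected in this assay, likely beyond the scatter but not large.

Compound 4 is therefore estimated to give 45 nM in this assay, within a range of 12 nM to 200 nM, which corresponds to an expected step of a 3.2-fold higher number from compound 1 to compound 4 (0.51 log units; beyond the scatter).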

Compound 4, half-maximal effective concentration: 278 nM
Estimate against measurement, compound 4: 6.2-fold (0.79 log units) below; measured number outside the range, above it.
By their numbers in this assay, from the lowest: compound 1; then compound 2; then compound 4.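

For the compounds shown here, replacing 1H-pyrazol-4-yl with 1-methyl-1H-pyrazol-5-yl on this aromatic carbon gives a 20-fold higher number from compound 1 to compound 4 (1.30 log units; beyond the scatter) in this assay, the first step in this set between compounds that differ in one place, and a large one. Going by these compounds alone, this position therefore distinguishes between two five-membered aromatic rings that both carry hetero atoms, so the result depends on more than the presence of such a ring, although the single exchange removes the hydrogen-bond donor, adds the methyl group and moves the point of attachment all at once. Nothing measured among these compounds gives a cause for this step.

The compounds shown leave open which of these differences carries the step, since 1-methyl-1H-pyrazol-4-yl, which would keep the attachment of compound 1 with the methyl group added, and 1H-pyrazol-5-yl, which would keep the donor with the attachment moved, do not stand among them. They also leave open how this aromatic carbon would respond to groups outside this ring type, such as an amine or a carboxylic acid.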